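A few compounds are considered here, and "the series" means these few. Any claim that something is new, unique, unknown or untested is made for them only; others in the source may bear on it.

Working notes on the chromane series in a functional assay on U-373MG ATCC cells (Homo sapiens) for inhibition, read by MTT assay, with a stated time of 72 h; a higher number here means a weaker inhibitor, a lower number a stronger inhibitor.

Compound 2 `CC1(C)CC(NC(=S)Nc2cccc(C#N)c2)c2cc(Cl)ccc2O1` stands lowest of the two numbers recorded, with 7000 nM. For the measured compounds named here, its nearest neighbour is compound 3 `CC1(C)CC(NC(=S)Nc2cccc(C#N)c2)c2cc(F)ccc2O1`, at 30000 nM; the one measured step, a 4.3-fold higher number from compound 2 to compound 3 (0.63 log units; beyond the scatter), comes from fluoro in place of chloro on an aromatic carbon and lies beyond the scatter. Compound 1 `CCOC(=O)NC1CC(C)(C)Oc2ccc(Cl)cc21` returns only a limit, > 100000 nM. That limit is the limit of > 100000 nM in this assay, at which 1 of the 3 values shown sits, and compound 1 lacks the whole thiourea part, carrying an ethyl carbamate instead.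

Compound 4 `CC(C)NC(=S)NC1CC(C)(C)Oc2ccc(Cl)cc21` keeps the chloro and the thiourea of compound 2 and changes only the far nitrogen substituent: isopropyl in place of 3-cyanophenyl on an amide-type nitrogen. Going by the values given here, no measured step touches this position, so the halogen step from compound 2 to compound 3 gives the size of a modest change but no direction for this one. Among the compounds with values here, the only guidance is that compound 1, which loses the aryl thiourea altogether, falls out of range, whereas compound 4 retains the thiourea. A loss of potency is therefore expected, of modest to intermediate size, with a real chance of a limit. Compound 4 is estimated at 30000 nM, range 8000 nM to 100000 nM, a step of a 4.3-fold higher number from compound 2 to compound 4 (0.63 log units; beyond the scatter) expected.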

Compound 4, half-maximal inhibitory concentration: 57000 nM
Estimate against measurement, compound 4: 1.9-fold (0.28 log units) below; the range from low to high includes it.
By their numbers in this assay, from the lowest: compound 2; then compounds 3 and 4 (each within the scatter of the next). At a limit, above all of these: compound 1.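

With the chloro held fixed, isopropyl in place of 3-cyanophenyl on an amide-type nitrogen gives an 8.1-fold higher number from compound 2 to compound 4 (0.91 log units; beyond the scatter), the first measured sign that this position responds to change and that, of these two groups, 3-cyanophenyl gives the lower number. The aromatic ring at this position is not needed for a measurable result, as compound 4 still returns a number, 57000 nM. A further step, an at least 1.7-fold lower number from compound 1 to compound 4 (0.24 log units; that floor lies within the scatter), has a floor within the scatter and cannot be read. Compound 1 remains a limit in this assay: the limit of > 100000 nM in this assay, at which 1 of the 4 values shown sits.

On these data alone, whether the higher number of compound 4 follows from losing the ring, the nitrile or both stays open, and an unsubstituted phenyl or a cyclohexyl on the same nitrogen would help to separate these. As far as these compounds go, the fluoro for chloro step is known only with 3-cyanophenyl in place, so its size with isopropyl is also open, as is the effect of a urea in place of the thiourea.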